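This account rests on a few compounds, and the source may have more. Where it says the series, first, only, none or still open, it means among the compounds named here.

In a functional assay on HT-29 cells (Homo sapiens) for antiproliferative activity, with a stated time of 48 h (a lower number here means a stronger inhibitor, a higher number a weaker inhibitor), compound 1 (`CCCCCc1cccc(NC(=O)NCCCCl)c1`) gives 28000 nM. Compound 2 (`CCCCC(OC)c1cccc(NC(=O)NCCCCl)c1`), which carries a methoxy on the chain, gives 56000 nM. The step of a 2.0-fold higher number from compound 1 to compound 2 (0.30 log units; within the scatter) leaves compound 2 level with compound 1 within the scatter. Compound 3 (`CCCCC(OC)c1cccc(NC(=O)CCCCl)c1`) differs from compound 2 at another place: 3-chloropropyl in place of (3-chloropropyl)amino on a carbonyl carbon. Here, 3-chloropropyl stands in place of (3-chloropropyl)amino on a carbonyl carbon. Among the compounds with values here, the one measured step concerns the methoxy and does not touch this place, so no measurement in this assay bears directly on the change. The expectation therefore starts from compound 2 at 56000 nM, with no size or direction predicted beyond the scatter, and the range is kept wide. The estimated step is a 1.1-fold higher number from compound 2 to compound 3 (0.03 log units; within the scatter). For compound 3 the expected value is 60000 nM, with an estimated range of 20000 nM to 160000 nM.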

Compound 3, half-maximal inhibitory concentration: > 100000 nM
Compound 3: only a limit was reported; the forecaster's own chance of this, stated with the estimate: 20%; middle value at least 1.6-fold (0.22 log units) away from the limit.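

In this assay compound 3 gives > 100000 nM, which is a limit of the assay and not a number. This is the first change shown on the carbonyl carbon, and it reads an at least 1.7-fold higher number from compound 2 to compound 3 (0.25 log units; that floor lies within the scatter), so taking out the nitrogen of (3-chloropropyl)amino, and with it the one hydrogen-bond donor of that group, gives no lower number. The size of this step remains unknown, because the reading for compound 3 ends at a limit: the limit of > 100000 nM in this assay, at which 1 of the 3 values shown sits.

The compounds shown leave open how the same change behaves without the methoxy on the chain, since compound 1 has no partner that differs from it at this place. They also leave open what a longer chain on the carbonyl carbon, or an amine in place of the chlorine, would give.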